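Methyl scan on the shared core of compound 1

The source may hold more compounds than are shown below. What is called first, only, known or untested is meant among the compounds shown, and "the series" means these compounds.

Compound 1 `C1CN=C(NC(C2CC2)C2CC2)C1` is the parent of the series. In an assay (Oryctolagus cuniculus) for displacement of a labelled ligand from Monoamine oxidase (Homo sapiens) (on this read-out higher numbers stand for weaker inhibition and lower numbers for stronger inhibition), compound 1 gives < 10000 nM, which is a limit of the assay and not a number. Compound 2 `CC1CCC(NC(C2CC2)C2CC2)=N1` carries a methyl in place of hydrogen on a saturated ring carbon. In this assay compound 2 gives < 10000 nM, again a limit. Compound 3 `CC1CCN=C1NC(C1CC1)C1CC1` carries the same change at a different saturated ring carbon. In this assay compound 3 gives < 10000 nM, also a limit. The step that the two limits leave unreadable from compound 1 to compound 2 and the step that the two limits leave unreadable from compound 1 to compound 3 therefore cannot be sized; all that the numbers show is the limit of < 10000 nM in this assay, at which 3 of the 3 values shown sit.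

Compound 4 `CC1CN=C(NC(C2CC2)C2CC2)C1` is yet to be measured. It differs from compound 1 by methyl in place of hydrogen on a saturated ring carbon. Both measured steps bear on it, and neither is readable, so no direction or size beyond the scatter can be expected from the numbers shown. The estimate for compound 4 is 3000 nM, within 300 nM to 30000 nM. The step this estimate means is a step that the limit leaves unreadable from compound 1 to compound 4, stated as an expectation only.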

Compound 4, inhibition constant: < 10000 nM
Compound 4 gave a limit, no number (the forecaster's own chance of this, stated with the estimate: 70%); the middle value lies beyond the limit too.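

Compound 4 adds no readable step from compound 1, and the limit leaves its size unknown; the values shown are limits and not numbers: the limit of < 10000 nM in this assay, at which 4 of the 4 values shown sit.

The compounds shown leave open whether a methyl on any saturated ring carbon of the shared core changes the inhibition constant, and in which direction.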